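The compounds below may be only part of what the source reports. "The series", "measured", "known", "first", "only" and "open" are said of these compounds alone.

Three compounds built on one shared core were tested in a functional assay on RPMI-8226 cells (Homo sapiens) for inhibition, read by sulforhodamine B assay, with a stated time of 48 h; a higher number here means a weaker inhibitor of growth, a lower number a stronger inhibitor of growth. Compound 1 `CCOC(=O)C(=Cc1c(-c2ccccc2)[nH]c2ccccc12)C(=O)OCC` gives 219 nM, compound 2 `O=C(/C(=C\c1c(-c2ccccc2)[nH]c2ccccc12)S(=O)(=O)c1ccccc1)c1ccccc1` gives 7600 nM, and compound 3 `COc1ccc(-c2[nH]c3ccc(OC)cc3c2C=C(C#N)C#N)cc1` gives 5100 nM. Compound 2 has the highest of the three numbers: its gap to compound 3 lies within the scatter, while its gap to compound 1 lies beyond it. Compound 4 `N#C/C(=C\c1c(-c2ccccc2)[nH]c2ccccc12)S(=O)(=O)c1ccccc1` differs from compound 2 in one place: cyano in place of benzoyl on a double-bonded chain carbon bound to a double-bonded chain carbon and a sulfonyl sulfur. Within the data shown here, no measured pair in this set isolates that change, so the direction of the step is uncertain. Compound 4 is expected to move only modestly, the estimated step being a 1.5-fold lower number from compound 2 to compound 4 (0.18 log units; within the scatter), which does not clearly exceed the scatter. For compound 4 in this assay the estimate is 5000 nM, with a range from 1500 nM to 16000 nM.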

Compound 4, concentration for 50% growth inhibition: 714 nM
Beside the measured number, compound 4's estimate is 7.0-fold (0.85 log units) above it, and the stated range ends above it.
By their numbers in this assay, from the lowest: compound 1; then compound 4; then compounds 3 and 2 (each within the scatter of the next).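

Placing cyano where benzoyl stood, on a double-bonded chain carbon bound to a double-bonded chain carbon and a sulfonyl sulfur, gives in this assay an 11-fold lower number from compound 2 to compound 4 (1.03 log units; beyond the scatter), the first change in this set isolated at a single place. It shows that the group held at this position can shift growth inhibition well beyond the scatter while the rest of the structure stays fixed. Nothing measured here accounts for the size of the step.

As far as these compounds go, whether a primary amide or a carboxylic acid at this position would match cyano remains open. So does whether the same exchange would give a similar step with another group in place of the phenylsulfonyl.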